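This account rests on a few compounds, and the source may have more. Where it says the series, first, only, none or still open, it means among the compounds named here.

Compound 1 `COc1ccc(C(=O)c2ccn(-c3ccc4c(c3)B(O)OC4)c2)cc1` gives in an ADME assay on L929 cells (Mus musculus) for cytotoxicity, read by resazurin assay, with a stated time of 72 h (on this read-out lower numbers stand for stronger inhibition and higher numbers for weaker inhibition), a limit of > 10 ug/mL. Compound 2 `O=C(c1ccc(CO)cc1)c1ccn(-c2ccc3c(c2)B(O)OC3)c1` gives in this assay 9.31 ug/mL.

Among the compounds with values here, compound 2 thus holds the only number measured here, the other result being a limit (the limit of > 10 ug/mL in this assay, at which 1 of the 2 values shown sits). Compound 3 `O=C(c1ccn(-c2ccc3c(c2)B(O)OC3)c1)C1CCCCC1` differs from compound 2 by cyclohexyl in place of 4-(hydroxymethyl)phenyl on a carbonyl carbon. Within the data shown here, the single measured step, an at least 1.0-fold lower number from compound 1 to compound 2 (0.03 log units; that floor lies within the scatter), lies within the scatter and concerns a different place, so it gives no direction for this change. Compound 3 is therefore expected to sit near compound 2 in this assay, at an estimated 9 ug/mL within 4 ug/mL to 20 ug/mL, a step of a 1.0-fold lower number from compound 2 to compound 3 (0.01 log units; within the scatter).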

Compound 3, half-maximal inhibitory concentration: > 10 ug/mL
Compound 3: only a limit was reported; the forecaster's own chance of this, stated with the estimate: 40%; middle value at least 1.1-fold (0.04 log units) from the limit.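

In this assay, cyclohexyl in place of 4-(hydroxymethyl)phenyl on a carbonyl carbon gives an at least 1.0-fold higher number from compound 2 to compound 3 (0.03 log units; that floor lies within the scatter), so this position tolerates a non-aromatic carbon ring without any lower number appearing, though the step is only a floor and not a size. The step from compound 1 to compound 3 cannot be read. Compound 3 ends at a limit, as does compound 1: the limit of > 10 ug/mL in this assay, at which 2 of the 3 values shown sit.

On these data alone, how far the true values of compound 1 and compound 3 lie from that limit stays open. So does the outcome of an amine or a short chain such as ethyl on this carbonyl carbon.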